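The source may hold more compounds than are shown below. What is called first, only, known or untested is meant among the compounds shown, and "the series" means these compounds.

Measured so far:
Compound 1, `C[C@@H](Oc1cc2onc(CCC(=O)O)c2cc1Cl)c1ccc(Cl)cn1` — 8.7 h
Compound 2, `O=C(O)CCn1c(=O)oc2cc(OCC3CC3)c(Cl)cc21` — 0.68 h

Both numbers come from an ADME assay on the whole organism (strain Han-Wistar) for metabolic stability, with Rattus norvegicus as the target, read by LC-MS, at a dose of 1 mg/kg by the intravenous route; a higher number here means that the compound lasts longer, a lower number that the compound disappears faster. Of the two, compound 1 gives the longer half-life, and the gap to compound 2 lies well beyond the usual scatter of repeated measurements. Among the compounds with values here, no pair of measured compounds differs in only one place, so there is no single, clean step to learn from.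

Compound 3, `C[C@@H](Oc1cc2onc(CCC(=O)O)c2cc1Cl)c1ccccn1`, has not yet been measured. It differs from compound 1 in one place: hydrogen in place of chloro on an aromatic carbon. Within the data shown here, with no measured step of this kind to guide the guess, a modest change is expected, most likely toward a somewhat shorter half-life, and the step of a 1.7-fold lower number from compound 1 to compound 3 (0.24 log units; within the scatter) expresses that expectation. A result within the scatter of compound 1 would not be surprising either. In this assay compound 3 is therefore estimated at 5 h, with a likely range from 2 h to 12 h.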

Compound 3, half-life in the Rattus norvegicus assay: 6.6 h
Compound 3: the middle estimate sits 1.3-fold (0.12 log units) below what was measured; the range from low to high includes it.
By their numbers in the Rattus norvegicus assay, from the lowest: compound 2; then compounds 3 and 1 (each within the scatter of the next).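

In the Rattus norvegicus assay, the swap from 5-chloropyridin-2-yl to pyridin-2-yl gives a 1.3-fold lower number from compound 1 to compound 3 (0.12 log units; within the scatter), so at this position hydrogen can stand in for chloro with no change beyond the scatter. In a physicochemical assay for solubility, with a stated time of 24 h (a higher number here means a more soluble compound, a lower number a less soluble compound), compound 1 gives > 620 ug/mL, which is a limit of the assay and not a number. In the physicochemical assay, compound 3 gives > 7440 ug/mL, again a limit and not a number, so the step between these two compounds cannot be read.

Nothing shown here gives a cause for the result in half-life. As far as these compounds go, it remains open how a fluoro, a methoxy or a nitrile on this same aromatic carbon would read in the Rattus norvegicus assay, and where the true values of compound 1 and compound 3 lie in the physicochemical assay.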